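The source may report more compounds than this note shows. Statements on the series, on what has been measured and on what is new or still open speak of the compounds shown alone.

Measured in a physicochemical assay for solubility, at pH 6.8; on this read-out higher numbers stand for higher solubility and lower numbers for lower solubility:

- Compound 1 `CCC(=O)N[C@@H](C)c1ccc(NC(=O)[C@H]2C[C@@H]2c2cccnc2)cc1`: 54000 nM
- Compound 2 `C[C@H](NC(=O)C1CCOCC1)c1ccc(NC(=O)[C@H]2C[C@@H]2c2cccnc2)cc1`: 90000 nM
- Compound 3 `C[C@H](NC(=O)c1ccccc1)c1ccc(NC(=O)[C@H]2C[C@@H]2c2cccnc2)cc1`: < 4000 nM (a limit of the assay, not a number)

Compound 3 has only a limit and sits at the limit of < 4000 nM in this assay, at which 1 of the 3 values shown sits. Compound 4 `C[C@H](NC(=O)c1ncccn1)c1ccc(NC(=O)[C@H]2C[C@@H]2c2cccnc2)cc1` differs from it in one place: pyrimidin-2-yl in place of phenyl on a carbonyl carbon. In words, pyrimidin-2-yl stands in place of phenyl on a carbonyl carbon.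

Within the data shown here, no measured step brings pyrimidin-2-yl onto that carbon, so the estimate rests on neighbouring changes at the same place. Two steps that put phenyl there were large: an at least 13-fold lower number from compound 1 to compound 3 (1.13 log units; beyond the scatter), and an at least 22-fold lower number from compound 2 to compound 3 (1.35 log units; beyond the scatter). By contrast, the step between the two non-aromatic groups gave a 1.7-fold higher number from compound 1 to compound 2 (0.22 log units; within the scatter).

Compound 4 gives up the phenyl but keeps a six-membered aromatic ring, so a rise beyond the scatter is expected, with a return only part of the way towards compound 1 and compound 2. The estimated step is an at least 7.5-fold higher number from compound 3 to compound 4 (0.87 log units; beyond the scatter). For compound 4 the expected value is 30000 nM, with an estimated range of 8000 nM to 100000 nM.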

Compound 4, solubility: 27000 nM
For compound 4 the middle estimate is 1.1-fold (0.05 log units) above the measured one, within the range that was stated.
By their numbers in this assay, from the lowest: compounds 4, 1 and 2 (each within the scatter of the next, the first and the last beyond it). At a limit, below all of these: compound 3.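

In this assay, pyrimidin-2-yl in place of phenyl on a carbonyl carbon gives an at least 6.7-fold higher number from compound 3 to compound 4 (0.82 log units; beyond the scatter), so a six-membered aromatic ring at this place does not by itself keep the number low, as compound 3 alone might have suggested. Compound 3 stands at a limit of the assay, so that step is only a floor: the limit of < 4000 nM in this assay, at which 1 of the 4 values shown sits. Pyrimidin-2-yl still falls short of oxan-4-yl, with a 3.3-fold lower number from compound 2 to compound 4 (0.52 log units; beyond the scatter), but it is not separated from ethyl, with a 2.0-fold lower number from compound 1 to compound 4 (0.30 log units; within the scatter).

The compounds shown leave open whether a pyridinyl ring at this place would behave like pyrimidin-2-yl or like phenyl, so the contribution of the ring nitrogens cannot be read. They also leave open how an amine or a carboxylic acid on the aromatic ring would read here.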